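This account rests on a few compounds, and the source may have more. Where it says the series, first, only, none or still open, it means among the compounds named here.

Compound 1 `Cc1ccc(-c2csc(N/N=C/c3ccc(Cl)cc3Cl)n2)cc1` gives 80.4% in a functional assay, read by spectrophotometry, with a stated time of 15 min, tested at 40 ug/mL; on this read-out lower numbers stand for a weaker effect and higher numbers for a stronger effect at the one concentration tested.
Compound 2 `Fc1ccc(-c2csc(N/N=C/c3cccs3)n2)cc1` gives 87.5% in this assay.
Compound 3 `Cc1ccc(-c2csc(N/N=C/c3cccs3)n2)cc1` gives 82.8% in this assay.

The three measured compounds share a core and differ only in the two outer rings. Of the three, compound 1 returns the smallest number, yet its gap to compound 3 and its gap to compound 2 both lie within the scatter of repeated measurements, so the three cannot be told apart on these numbers.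

Compound 4 `Clc1ccc(/C=N/Nc2nc(-c3ccccc3)cs2)c(Cl)c1` has not yet been measured. It differs from compound 1 by hydrogen in place of methyl on an aromatic carbon. Among the measured compounds shown here, only one measured step touches that position: a number 4.7 percentage points lower from compound 2 to compound 3 (within the scatter), which swapped one small group for another on the same ring and stayed within the scatter. For the measured compounds named here, no measured pair shows what the loss of the methyl itself does. Going by the values given here, with the one related step showing no movement, the step from compound 1 to compound 4 is expected to be a number 1.4 percentage points lower from compound 1 to compound 4 (within the scatter), without a change beyond the scatter in either direction. Compound 4 is therefore estimated to give 79% in this assay, with a range from 66% to 91%.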

Compound 4, a percentage reported as inhibition, at one concentration (the size of the read-out at that concentration, not a potency): 78.9%
Compound 4: the middle estimate sits 0.1 percentage points above what was measured, within the range that was stated.
By their numbers in this assay, from the lowest: compounds 4, 1, 3 and 2 (each within the scatter of the next).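

Among the compounds shown here, compound 4 gives the first direct reading of what happens when the methyl is simply removed, rather than exchanged for another small group: the change from 4-methylphenyl to phenyl, with the rest of compound 1 left as it is, gives a number 1.5 percentage points lower from compound 1 to compound 4 (within the scatter) in this assay. Together with a number 4.7 percentage points lower from compound 2 to compound 3 (within the scatter), this means that neither of the two single changes at this place on the ring moves the number beyond the scatter, although each was read against a different outer ring on the other side of the molecule. Nothing available here offers an explanation for why the number holds when the methyl is lost.

The compounds shown carry only hydrogen, methyl or fluoro at this place, so it remains open whether a quite different group there, such as an amine, a carboxylic acid or a longer chain, would move the number beyond the scatter. Also open is whether losing the methyl from compound 3 would read the same way, and, since each number comes from a single concentration, how the potencies of these compounds compare.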